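A chloro group gives way to a methyl group

The source may report more compounds than this note shows. Statements on the series, on what has been measured and on what is new or still open speak of the compounds shown alone.

In a functional assay on HCT-116 cells (Homo sapiens) for antiproliferative activity, read by MTT assay, with a stated time of 48 h (on this read-out higher numbers stand for weaker inhibition and lower numbers for stronger inhibition), compound 1 (`COc1ccc(CN(C(=O)CSc2nc3ccccc3s2)c2cc(OC)c(OC)c(OC)c2)cc1O`) gives 182 nM and compound 2 (`COc1ccc(CN(C(=O)CSc2nc3cc(Cl)ccc3s2)c2cc(OC)c(OC)c(OC)c2)cc1O`) gives 429 nM as its reading. Compound 2 therefore holds the higher of the two numbers and is the weaker inhibitor of the pair. Compound 3 (`COc1ccc(CN(C(=O)CSc2nc3c(C)cccc3s2)c2cc(OC)c(OC)c(OC)c2)cc1O`) differs from compound 2 in the group on the sulfur. The change is 4-methyl-1,3-benzothiazol-2-yl in place of 5-chloro-1,3-benzothiazol-2-yl on a sulfur and amounts to 4-methyl-1,3-benzothiazol-2-yl in place of 5-chloro-1,3-benzothiazol-2-yl on a sulfur whose other neighbour is a saturated chain carbon. Among the compounds with values here, one measured step bears on this, namely a 2.4-fold higher number from compound 1 to compound 2 (0.37 log units; beyond the scatter) with chloro in place of hydrogen on an aromatic carbon. That step is modest. Within the data shown here, compound 3 carries no chloro, so part of that step may be given back, although no measured step speaks to the methyl group. A modest move toward lower numbers in this assay is therefore expected, with the estimated change being a 1.7-fold lower number from compound 2 to compound 3 (0.22 log units; within the scatter) overall. The estimate for compound 3 is 260 nM and the value is expected to fall between 100 nM and 650 nM in this assay.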

Compound 3, half-maximal inhibitory concentration: 852 nM
For compound 3 the middle estimate is 3.3-fold (0.52 log units) below the measured one; the measured number lies above the stated range.
By their numbers in this assay, from the lowest: compound 1; then compounds 2 and 3 (each within the scatter of the next).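

Exchanging the 5-chloro-1,3-benzothiazol-2-yl on the sulfur for 4-methyl-1,3-benzothiazol-2-yl gives a 2.0-fold higher number from compound 2 to compound 3 (0.30 log units; within the scatter), so this assay does not set these two compounds apart, and losing the chloro does not by itself restore the reading of compound 1. Set against the hydrogen of compound 1, the methyl group gives a 4.7-fold higher number from compound 1 to compound 3 (0.67 log units; beyond the scatter), so among the three compounds shown, both the chloro and the methyl compound read higher than the compound carrying neither group, and none of the three goes against this. Nothing at hand on these compounds accounts for either step.

On these data alone, what stays open is how much of the exchange belongs to the group and how much to its place, as the chloro and the methyl group occupy different positions in the two names and neither group is seen at the other's position. As far as these compounds go, it is also open whether any group on these aromatic carbons would match or better the hydrogen of compound 1, such as a methoxy group, an amine or a carboxylic acid.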